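Chromone acrylamide series: amide substituent change from compound 1

This account rests on a few compounds, and the source may have more. Where it says the series, first, only, none or still open, it means among the compounds named here.

Compound 1 `COc1ccc2c(=O)c(/C=C/C(=O)Nc3cccc(Cl)c3)coc2c1` is the stronger of the two measured compounds in a functional assay on A549 cells (Homo sapiens) for inhibition, read by MTT assay, with a stated time of 48 h (on this read-out higher numbers stand for weaker inhibition and lower numbers for stronger inhibition), where compound 1 gives 470 nM. Among the compounds with values here, the only comparison available is to compound 2 `COc1ccc2c(=O)c(/C=C/C(=O)Nc3ccccc3)coc2c1`, which in this assay gives 51000 nM; the step of a 110-fold higher number from compound 1 to compound 2 (2.04 log units; beyond the scatter) comes from hydrogen in place of chloro on an aromatic carbon, so the halogen on the amide substituent carries much of the measured potency here. Compound 3 `COc1ccc2c(=O)c(/C=C/C(=O)NCc3cccc(F)c3)coc2c1` carries the change (3-fluorobenzyl in place of 3-chlorophenyl on an amide-type nitrogen). Within the data shown here, the measured step bears on it only in part: a halogen is kept on the ring, but the ring is moved out by one carbon and chloro becomes fluoro, and no measured pair reports either of these alone. The expected outcome is therefore a weaker result than compound 1, with a wide range, as a 6.4-fold higher number from compound 1 to compound 3 (0.81 log units; beyond the scatter) expresses. Compound 3 is estimated at 3000 nM, between 500 nM and 25000 nM.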

Compound 3, half-maximal inhibitory concentration: 26900 nM
Estimate against measurement, compound 3: 9.0-fold (0.95 log units) below; the whole stated range lies below it.
By their numbers in this assay, from the lowest: compound 1; then compounds 3 and 2 (each within the scatter of the next).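

In this assay, 3-fluorobenzyl in place of 3-chlorophenyl on the amide-type nitrogen gives a 57-fold higher number from compound 1 to compound 3 (1.76 log units; beyond the scatter) and so does not retain the potency of compound 1, which shows that a halogen on the ring is not enough by itself. Compared with the unsubstituted phenyl group on the same nitrogen, the change gives a 1.9-fold lower number from compound 2 to compound 3 (0.28 log units; within the scatter) and does not separate 3-fluorobenzyl from phenyl on this read-out. No evidence at hand accounts for either step.

On these data alone, the change from phenyl to benzyl and the change from chloro to fluoro arrive together in compound 3, so their separate contributions remain open, and a 3-chlorobenzyl or 3-fluorophenyl group on that nitrogen would part them. Also open, as far as these compounds go, is how bromo or methoxy on the ring would compare with chloro.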